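The source may hold more compounds than are shown below. What is called first, only, known or untested is meant among the compounds shown, and "the series" means these compounds.

Measured compounds in a functional assay on CNE-2 cells (Homo sapiens) for inhibition, read by MTT assay, with a stated time of 72 h; on this read-out lower numbers stand for stronger inhibition and higher numbers for weaker inhibition:
Compound 1 `Nc1ncnc2c1c(-c1cnc3[nH]ccc3c1)nn2CCCCCCC(=O)NO` gives 19500 nM.
Compound 2 `Nc1ncnc2c1c(-c1cnc3[nH]ccc3c1)nn2CCCCCCCCCC(=O)NO` gives 2200 nM.
Compound 3 `Nc1ncnc2c1c(-c1cnc3[nH]ccc3c1)nn2CCCCCC(=O)NO` gives only a limit of the assay, > 50000 nM, as noted in the limit of > 50000 nM in this assay, at which 1 of the 3 values shown sits.

Compound 1 stands highest of the two numbers; its nearest neighbour is compound 2, with an 8.9-fold lower number from compound 1 to compound 2 (0.95 log units; beyond the scatter). Compound 4 `Nc1nc2cc(-c3nn(CCCCCCC(=O)NO)c4ncnc(N)c34)ccc2o1` differs from compound 1 by a group of 10 heavy atoms (7 carbon, 2 nitrogen, 1 oxygen; one five-membered aromatic ring with 2 hetero atoms, one six-membered aromatic ring of carbon only) in place of a group of 9 heavy atoms (7 carbon, 2 nitrogen; one five-membered aromatic ring with 1 hetero atom, one six-membered aromatic ring with 1 hetero atom), on an aromatic carbon.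

Among the measured compounds shown here, none of the measured steps bears on this change: an 8.9-fold lower number from compound 1 to compound 2 (0.95 log units; beyond the scatter), an at least 2.5-fold higher number from compound 1 to compound 3 (0.40 log units; beyond the scatter) and an at least 22-fold higher number from compound 2 to compound 3 (1.35 log units; beyond the scatter) all alter the hydroxycarbamoyl chain, while the aromatic group at this position stays the same throughout. The step for compound 4 is therefore expected to be none beyond the scatter, with wide uncertainty in both directions. Compound 4 is estimated at 19500 nM, expected between 5000 nM and 60000 nM, meaning no change at the digits printed from compound 1 to compound 4 (within the scatter).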

Compound 4, half-maximal inhibitory concentration: 4360 nM
For compound 4 the middle estimate is 4.5-fold (0.65 log units) above the measured one; measured number outside the range, below it.
By their numbers in this assay, from the lowest: compounds 2 and 4 (each within the scatter of the next); then compound 1. At a limit, above all of these: compound 3.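

With 2-amino-1,3-benzoxazol-5-yl on this aromatic carbon, the result is a 4.5-fold lower number from compound 1 to compound 4 (0.65 log units; beyond the scatter) in this assay, so the read-out responds to this position as well as to the hydroxycarbamoyl chain. The earlier compounds shown here, which all carry the same aromatic group here, could not show this. Nothing measured here accounts for the change.

From the compounds shown here alone, it remains open whether 2-amino-1,3-benzoxazol-5-yl would bring a similar step on the longer chain of compound 2. Also open, going by these compounds, is whether its amine matters, which a benzoxazol-5-yl group without that amine would test.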